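A few compounds are considered here, and "the series" means these few. Any claim that something is new, unique, unknown or untested is made for them only; others in the source may bear on it.

- Compound 1 `COc1cccc(N2CCN(CCCCN3C(=O)CC(C)(C)CC3=O)CC2)n1`: 76.2 mg/kg
- Compound 2 `COc1cccnc1N1CCN(CCCCN2C(=O)SC3(CCCC3)C2=O)CC1`: < 57 mg/kg, a limit
- Compound 3 `O=C1COCC(=O)N1CCCCN1CCN(c2ncccc2Cl)CC1`: > 63 mg/kg, a limit

In a functional assay on the whole organism for inhibition, with Rattus norvegicus as the target (on this read-out lower numbers stand for an effect already at smaller amounts and higher numbers for an effect only at larger amounts of compound), only compound 1 has a true number. From the compounds shown here alone, compound 2 gives < 57 mg/kg, which is a limit of the assay and not a number, so its exact place on the scale remains open.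

Compound 4 `O=C1SC2(CCCC2)C(=O)N1CCCCN1CCN(c2ncccc2Cl)CC1` differs from compound 2 at one place, with chloro in place of methoxy on an aromatic carbon, ortho to a large group and two atoms from the ring nitrogen (chloro in place of methoxy on an aromatic carbon). The same difference reads 3-methoxypyridin-2-yl to 3-chloropyridin-2-yl.

Compound 3 also carries 3-chloropyridin-2-yl, but its > 63 mg/kg is only a limit and offers no number to lean on. Within the data shown here, no measured pair shows this exchange, so no change beyond the usual scatter is expected in this assay, in either direction. The expected step that the limit leaves unreadable from compound 2 to compound 4 is therefore small. Compound 4 is estimated at 45 mg/kg, with an expected range of 18 mg/kg to 100 mg/kg.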

Compound 4, dose for half-maximal effect: 50 mg/kg
Compound 4: middle estimate off by 1.1-fold (0.05 log units), on the low side; the measured number falls inside the stated range.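

No step can be read from compound 2 to compound 4, because the value for compound 2 is a limit and not a number: the limit of < 57 mg/kg in this assay, at which 1 of the 4 values shown sits.

The compounds shown leave open whether chloro in place of methoxy changes the dose needed in this assay at all, and in which direction.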